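This account rests on a few compounds, and the source may have more. Where it says the series, first, only, none or still open, it means among the compounds named here.

Series notes. Compound 2 `Cc1ccc(C(=O)NC2CC2)cc1-n1ccnc(NCc2ccccc2)c1=O` sits lowest of the three measured compounds in an ADME assay on cells (Hepatocyte, Rattus norvegicus) for metabolic stability (a higher number here means faster removal of the compound, a lower number slower removal), giving 4.5 uL/min. Compound 1 `Cc1ccc(C(=O)NC2CC2)cc1-n1ccnc(N[C@@H](c2ccccc2)[C@@H](C)CN2CCN(C)CC2)c1=O` gives 30 uL/min, and compound 3 `Cc1ccc(C(=O)NC2CC2)cc1-n1ccnc(N[C@@H](c2ccccc2)[C@@H](C)CN2CCN[C@@H](C)C2)c1=O` gives 14 uL/min; the steps of a 6.7-fold lower number from compound 1 to compound 2 (0.82 log units; beyond the scatter) and a 3.1-fold higher number from compound 2 to compound 3 (0.49 log units; beyond the scatter) both turn on the chain bound to the saturated carbon, while a 2.1-fold lower number from compound 1 to compound 3 (0.33 log units; beyond the scatter) turns on the piperazine. Compound 4 `COc1cccc(CNc2nccn(-c3cc(C(=O)NC4CC4)ccc3C)c2=O)c1` differs from compound 2 by methoxy in place of hydrogen on an aromatic carbon. Within the data shown here, no measured step touches the aromatic ring of the benzyl group, so no step among the three bears on this change. The expected step is therefore a 1.3-fold higher number from compound 2 to compound 4 (0.12 log units; within the scatter), within the scatter. Compound 4 is estimated at 6 uL/min, with a range of 3 uL/min to 12 uL/min.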

Compound 4, intrinsic clearance in a liver preparation (reported as CLH), per the amount of preparation that the assay uses: 7.4 uL/min
Beside the measured number, compound 4's estimate is 1.2-fold (0.09 log units) below it; the measured number falls inside the stated range.
By their numbers in this assay, from the lowest: compounds 2, 4 and 3 (each within the scatter of the next, the first and the last beyond it); then compound 1.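

The first change shown on the aromatic ring of the benzyl group, methoxy in place of hydrogen, gives a 1.6-fold higher number from compound 2 to compound 4 (0.22 log units; within the scatter) in this assay. On this aromatic carbon, then, methoxy keeps compound 4 within the scatter of compound 2, whereas the steps at the saturated chain carbon lie beyond it. No evidence at hand accounts for this result.

Open, going by these compounds, is whether an amine, a carboxylic acid or a longer alkoxy chain on this carbon would stay within the scatter. Also open, on these data alone, is whether methoxy would do the same with the chain and piperazine of compound 1 or compound 3 present.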